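Swapping a Pyridine for an Imidazole on the Shared Core

This account rests on a few compounds, and the source may have more. Where it says the series, first, only, none or still open, it means among the compounds named here.

Of the compounds shown here, three built on one shared core have been tested in an ADME assay on THP-1 cells (Homo sapiens) for cytotoxicity; a higher number here means that more compound is tolerated, a lower number that less compound is tolerated. Compound 1 `N#Cc1ccc(Nc2c(-c3ccccn3)nc3ccccn23)cc1` gives only a limit of the measurement, > 50000 nM. Compound 2 `COc1ccc(Nc2c(-c3ccccn3)nc3ccc(C)cn23)cc1` gives 10700 nM in this assay. Compound 3 `Cc1cc(-c2nc3ccccn3c2NC2CCCC2)ccn1` also gives only a limit in this assay, > 50000 nM. Compound 3 thus stands together with compound 1 at the limit of > 50000 nM in this assay, at which 2 of the 3 values shown sit, and only compound 2 yields an actual number. No two of these compounds differ in just one place, so no single measured step can be read out among them.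

Compound 4 `Cn1ccnc1-c1nc2ccccn2c1NC1CCCC1` has not yet been measured. It differs from compound 3 by 1-methyl-1H-imidazol-2-yl in place of 2-methylpyridin-4-yl on an aromatic carbon. For the measured compounds named here, with no measured step to lean on, no shift beyond the usual scatter is expected, and the reading is expected to sit at the limit again. Compound 4 is therefore estimated at 50000 nM, with a range from 20000 nM to 100000 nM. The step this estimate implies, a number no higher from compound 3 to compound 4 (the limit leaves the size open), is expected to be none beyond the scatter.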

Compound 4, half-maximal cytotoxic concentration: > 50000 nM
Compound 4: no number, only a limit; the forecaster's own chance of this, stated with the estimate: 70%; the middle value lies on the limit itself.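

Compound 4 gives only a limit in this assay, and compound 3 does too, so no step between them can be read: the limit of > 50000 nM in this assay, at which 3 of the 4 values shown sit.

The compounds shown leave open whether 1-methyl-1H-imidazol-2-yl in place of 2-methylpyridin-4-yl changes the tolerated concentration at all.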